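A 4-aminophenyl group in place of thiophen-2-yl

The source may hold more compounds than are shown below. What is called first, only, known or untested is meant among the compounds shown, and "the series" means these compounds.

Measured in a functional assay on HCT-116 cells (Homo sapiens) for inhibition, read by MTT assay, with a stated time of 48 h; on this read-out higher numbers stand for weaker inhibition and lower numbers for stronger inhibition:
- compound 1 `COc1cc(-c2cc(-c3cccc([N+](=O)[O-])c3)nc(-c3ccccc3)n2)cc(OC)c1OC`: > 25000 nM, a limit of the assay and not a number
- compound 2 `COc1cc(-c2cc(-c3ccc(O)cc3O)nc(-c3ccccc3)n2)cc(OC)c1OC`: 5890 nM
- compound 3 `COc1cc(-c2cc(-c3cccs3)nc(-c3ccccc3)n2)cc(OC)c1OC`: 17000 nM

Of the two actual numbers in this assay, compound 3 has the higher, 17000 nM, so it shows the weaker inhibition of that pair. The next compound, compound 4 `COc1cc(-c2cc(-c3ccc(N)cc3)nc(-c3ccccc3)n2)cc(OC)c1OC`, carries 4-aminophenyl in place of thiophen-2-yl on an aromatic carbon.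

Three measured steps change this same carbon: a 2.9-fold higher number from compound 2 to compound 3 (0.46 log units; beyond the scatter), an at least 4.2-fold lower number from compound 1 to compound 2 (0.62 log units; beyond the scatter) and an at least 1.4-fold lower number from compound 1 to compound 3 (0.16 log units; that floor lies within the scatter). Compound 4 keeps a substituted phenyl there, as compound 2 does with 2,4-dihydroxyphenyl at 5890 nM, so a modest move to a lower number is expected. Compound 1, with 3-nitrophenyl, goes against reading every substituted phenyl as a gain, so the expectation stays loose.

The expected change is a 2.1-fold lower number from compound 3 to compound 4 (0.33 log units; beyond the scatter). For compound 4 the estimate is 8000 nM, with an expected range from 2500 nM to 25000 nM.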

Compound 4, half-maximal inhibitory concentration: 12300 nM
Estimate against measurement, compound 4: 1.5-fold (0.19 log units) below; low and high end bracket the measured number.
By their numbers in this assay, from the lowest: compound 2; then compounds 4 and 3 (each within the scatter of the next). At a limit, above all of these: compound 1.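

In this assay, 4-aminophenyl in place of thiophen-2-yl gives a 1.4-fold lower number from compound 3 to compound 4 (0.14 log units; within the scatter), so at this carbon the six-membered carbon ring with its amine cannot be told apart from the five-membered sulfur ring. Against 2,4-dihydroxyphenyl the same group gives a 2.1-fold higher number from compound 2 to compound 4 (0.32 log units; beyond the scatter), which leaves compound 2 ahead of both compound 3 and compound 4 and shows that a substituted phenyl here does not by itself match compound 2. Compound 1 stands at a limit and not at a number, so an at least 2.0-fold lower number from compound 1 to compound 4 (0.30 log units; that floor lies within the scatter) gives only a floor: the limit of > 25000 nM in this assay, at which 1 of the 4 values shown sits.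

The compounds shown leave open whether the edge of compound 2 needs both hydroxyl groups or would survive with 4-hydroxyphenyl or 2-hydroxyphenyl alone. From the compounds shown here alone, how a carboxylic acid or a methoxy group on this phenyl would read in this assay also remains open.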